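Cytotoxicity notes: ring closure of the side-chain amine

The source may report more compounds than this note shows. Statements on the series, on what has been measured and on what is new or still open speak of the compounds shown alone.

The series shares the core of compound 1 `NCCNc1cc(N2CCCc3ccccc3C2)nc2ccc(Cl)cc12`. In an ADME assay on HEp-2 cells (Homo sapiens) for cytotoxicity, read by CCK-8 assay, with a stated time of 5 days (on this read-out lower numbers stand for higher toxicity in this test and higher numbers for lower toxicity in this test), compound 1 gives > 3200 nM, a limit of the assay rather than a number. Compound 2 `COc1ccc2nc(N3CCCc4ccccc4C3)cc(NCCN)c2c1` gives 4800 nM in this assay. Compound 3 `Cc1ccc2nc(N3CCCc4ccc(F)cc4C3)cc(NCC(C)N)c2c1` gives 86000 nM in this assay, the highest of the two numbers shown; compound 2 sits well below it, beyond the scatter. Among the measured compounds shown here, the only single-point step that has been read, a step that the limit leaves unreadable from compound 1 to compound 2, cannot be sized because it starts from the limit of > 3200 nM in this assay, at which 1 of the 3 values shown sits.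

Compound 4 `Cc1ccc2nc(N3CCCc4ccc(F)cc4C3)cc(NCC3CCCCN3)c2c1` differs from compound 3 by piperidin-2-yl in place of 1-aminoethyl on a saturated chain carbon bound to a nitrogen on an aromatic ring. For the measured compounds named here, no measured step touches this part of the molecule: the step from compound 1 to compound 2 changes a ring substituent, and the pair compound 2 to compound 3 changes several places at once, so only their two values can be set side by side. Without a comparable step, the expectation for this assay is no movement beyond the scatter, and the step from compound 3 to compound 4 is estimated as a 1.2-fold lower number from compound 3 to compound 4 (0.09 log units; within the scatter). Compound 4 is therefore expected to give 70000 nM in this assay, with a range from 25000 nM to 200000 nM.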

Compound 4, half-maximal cytotoxic concentration: 23000 nM
Compound 4: middle estimate off by 3.0-fold (0.48 log units), on the high side; measured number below the stated range.
By their numbers in this assay, from the lowest: compound 2; then compound 4; then compound 3.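

Among the compounds shown here, this is the first readable step at this place, on a saturated chain carbon bound to a nitrogen on an aromatic ring: in this assay, piperidin-2-yl in place of 1-aminoethyl gives a 3.7-fold lower number from compound 3 to compound 4 (0.57 log units; beyond the scatter). The change therefore registers in this read-out, with the amine-bearing group now held in a six-membered non-aromatic ring and the number moving in the direction that stands for higher toxicity in this test, although a single pair sets no pattern for the series. No measurement shown bears on why this step occurs.

The pair cannot separate the effect of the ring from that of the larger group, and an open chain such as 1-aminobutyl or a smaller ring such as pyrrolidin-2-yl at the same place would be needed to tell them apart. On these data alone, it also remains open whether the step recurs with other substituents on the shared core, such as the chloro of compound 1 or the methoxy of compound 2, since it has been read only on the background common to compound 3 and compound 4.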